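The compounds below may be only part of what the source reports. "The series", "measured", "known", "first", "only" and "open" are said of these compounds alone.

Measured compounds:

compound 1, `CCCCOC(=O)Nc1ccc([Se]C#N)cc1`: 17200 nM
compound 2, `N#C[Se]c1ccc(NC(=O)Oc2ccc(F)cc2)cc1`: 25000 nM

Both compounds share the selenocyanate-bearing core; compound 1 carries a butyl carbamate, compound 2 an aryl carbamate. In a functional assay on HTB-54 cells (Homo sapiens) for cytotoxicity, read by MTT assay, with a stated time of 72 h (on this read-out lower numbers stand for stronger inhibition of growth and higher numbers for weaker inhibition of growth), compound 1 gives 17200 nM, the lowest of the two numbers, while compound 2 gives 25000 nM; the two values sit within the scatter of each other, so no order can be read between them.

The next compound is compound 3, `CCOC(=O)Nc1ccc([Se]C#N)cc1`. It differs from compound 1 in one place: hydrogen in place of ethyl on a saturated chain carbon, two bonds along the chain from an oxygen next to a carbonyl group. In plain terms the butyl chain of the carbamate is cut back to an ethyl chain, and nothing else on the core changes.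

For the measured compounds named here, no measured pair isolates this kind of chain trimming, so there is no internal step to lean on. With both measured values lying close together, the working expectation is that the step from compound 1 to compound 3 in this assay is small, most likely no larger than the scatter, and if anything leaning toward a somewhat higher number. The estimate for compound 3 is accordingly 22000 nM, within 8000 nM to 55000 nM, which is expected to correspond to a step of a 1.3-fold higher number from compound 1 to compound 3 (0.11 log units; within the scatter).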

Compound 3, concentration for 50% growth inhibition: 24900 nM
Beside the measured number, compound 3's estimate is 1.1-fold (0.05 log units) below it; the range from low to high includes it.
By their numbers in this assay, from the lowest: compounds 1, 3 and 2 (each within the scatter of the next).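

In this assay, trimming butyl to ethyl on a saturated chain carbon, two bonds along the chain from an oxygen next to a carbonyl group, gives a 1.4-fold higher number from compound 1 to compound 3 (0.16 log units; within the scatter). For the compounds shown here, this is the first pair that differs in one place, and it gives the first direct reading at this position: across this change, compound 1 and compound 3 cannot be told apart, so nothing here shows that the difference between a butyl and an ethyl chain matters in this read-out. No independent measurement bears on this result, and the step therefore stands without an explanation.

Still open, as far as these compounds go, is whether a chain longer than butyl, a methyl group, or a chain ending in an amine or a carboxylic acid would also stay within the scatter of compound 1 at this position. Also open, from the compounds shown here alone, is whether the same trimming would leave the read-out equally undisturbed on a different core or in a different cell line.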